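Chloro Substituent Tried on a Second Core

The compounds below may be only part of what the source reports. "The series", "measured", "known", "first", "only" and "open" are said of these compounds alone.

Compound 1 `CCC(=O)N1N=C(c2ccccc2)CC1c1ccc(Cl)cc1` and compound 2 `CCC(=O)N1N=C(c2ccc(Cl)cc2)CC1c1ccc(Cl)cc1` share a core and differ only in one way: chloro in place of hydrogen on an aromatic carbon. In an assay on isolated protein for inhibition of Amine oxidase [flavin-containing] A (Bos taurus) (a lower number here means a stronger inhibitor, a higher number a weaker inhibitor), compound 1 gives 200 nM, and compound 2 gives 200 nM. Compound 3 `CCC(=O)N1N=C(c2ccc(OC)cc2)CC1c1ccccc1` is built on a different core; how the two cores differ is not broken down here. In this assay compound 3 gives 63100 nM, the highest of the three numbers. Compound 4 `CCC(=O)N1N=C(c2ccc(OC)cc2)CC1c1ccc(Cl)cc1` differs from compound 3 in the same way, (chloro in place of hydrogen on an aromatic carbon), the same change as that between compound 1 and compound 2. Because the earlier pair showed no change at the digits printed from compound 1 to compound 2 (within the scatter), the step from compound 3 to compound 4 is expected to be similarly flat, a 1.1-fold lower number from compound 3 to compound 4 (0.02 log units; within the scatter). Compound 4 is therefore estimated to give 60000 nM in this assay, expected to lie between 20000 nM and 180000 nM.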

Compound 4, half-maximal inhibitory concentration: 832 nM
Compound 4: the middle estimate sits 72-fold (1.86 log units) above what was measured; measured number outside the range, below it.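

In this assay the chloro change does not carry over from one core to the other, so its effect depends on the core it is placed on: the same change on two cores in this assay, no change at the digits printed (within the scatter) from compound 1 to compound 2 and a 76-fold lower number (1.88 log units; beyond the scatter) from compound 3 to compound 4, 76-fold (1.88 log units) apart, beyond the scatter of two such steps On the core of compound 3 the change gives a 76-fold lower number from compound 3 to compound 4 (1.88 log units; beyond the scatter), yet the methoxy compound remains weaker than its two chloro-bearing relatives, with a 4.2-fold higher number from compound 2 to compound 4 (0.62 log units; beyond the scatter) and a 4.2-fold higher number from compound 1 to compound 4 (0.62 log units; beyond the scatter). Going by these compounds alone, this shows only that the two cores responded differently, not why they did so or how a third core would respond.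

From the compounds shown here alone, whether a bromo group or an amine in place of that chloro would give a similar gain on the core of compound 3 stays open. So does the effect of a longer chain in place of the methoxy group.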